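The source may hold more compounds than are shown below. What is called first, only, known or untested is meant among the compounds shown, and "the series" means these compounds.

Measured compounds in a functional assay on MCF7 cells (Homo sapiens) for antiproliferative activity; a lower number here means a stronger inhibitor, a higher number a weaker inhibitor:
compound 1 `COc1cc(Cc2nc3c(N)nc(F)nc3n2CCOC(C)C)cc(OC)c1OC` gives 15800 nM
compound 2 `C#CCCCn1c(Cc2cc(OC)c(OC)c(OC)c2)nc2c(N)nc(F)nc21` gives 11000 nM
compound 3 `COc1cc(Cc2nc3c(N)nc(F)nc3n2CC2CCCO2)cc(OC)c1OC` gives 22900 nM

Compound 3 carries the highest number of the three. Its distance from compound 1 is small, as the step of a 1.4-fold higher number from compound 1 to compound 3 (0.16 log units; within the scatter) shows, whereas the step of a 2.1-fold higher number from compound 2 to compound 3 (0.32 log units; beyond the scatter) goes beyond the scatter, so compound 3 is a weaker inhibitor than compound 2 in this assay, but cannot be set apart from compound 1.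

Compound 4 `C#CCCn1c(Cc2cc(OC)c(OC)c(OC)c2)nc2c(N)nc(F)nc21` is the next member. It differs from compound 3 in one place: propargyl in place of oxolan-2-yl on a saturated chain carbon bound to an aromatic nitrogen.

Among the measured compounds shown here, two measured steps touch the same chain on the aromatic nitrogen. The step of a 1.4-fold lower number from compound 1 to compound 2 (0.16 log units; within the scatter) stays within the scatter. The step of a 2.1-fold higher number from compound 2 to compound 3 (0.32 log units; beyond the scatter) is the closest model, since compound 4 carries the same terminal triple bond as compound 2, only on a shorter chain; read backwards, it points to a modest lower number on removing the oxolan-2-yl ring. For the measured compounds named here, no measured pair shows what shortening the chain by one carbon does, so the expectation leans on compound 2 alone.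

Compound 4 is therefore expected to show a modest lower number than compound 3, the expected step being a 1.9-fold lower number from compound 3 to compound 4 (0.28 log units; within the scatter). The estimate for compound 4 in this assay is 12000 nM, with a range from 5000 nM to 30000 nM.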

Compound 4, half-maximal inhibitory concentration: 25100 nM
Compound 4: middle estimate off by 2.1-fold (0.32 log units), on the low side; measured number inside the range.
By their numbers in this assay, from the lowest: compounds 2, 1, 3 and 4 (each within the scatter of the next, the first and the last beyond it).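

In this assay, but-3-yn-1-yl on the aromatic nitrogen cannot be set apart from (oxolan-2-yl)methyl (a 1.1-fold higher number from compound 3 to compound 4 (0.04 log units; within the scatter)) or from the isopropoxy-bearing chain of compound 1 (a 1.6-fold higher number from compound 1 to compound 4 (0.20 log units; within the scatter)), so neither of these changes at this place moves the read-out beyond the scatter. Among the compounds shown here, the terminal triple bond alone therefore does not go with the lower number of compound 2: ethynyl in place of propargyl on a saturated chain carbon, two bonds along the chain from an aromatic nitrogen, gives the only new step beyond the scatter (a 2.3-fold higher number from compound 2 to compound 4 (0.36 log units; beyond the scatter)), which makes compound 4 a modestly weaker inhibitor than compound 2 and shows that chain length can register, on the evidence of this single pair. No available evidence accounts for this difference or for the lack of separation in the other two steps.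

On these data alone, whether a longer chain ending in the triple bond would extend the trend from compound 4 to compound 2 remains open. Also open, as far as these compounds go, is whether an amine or a carboxylic acid on the saturated chain carbon bound to the aromatic nitrogen would move the number outside the narrow band occupied by these four compounds.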